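Fluorine Added to the Core of Compound 2

This account rests on a few compounds, and the source may have more. Where it says the series, first, only, none or still open, it means among the compounds named here.

Measured compounds:
compound 1, `CCC(C)n1ncn(-c2ccc(N3CCN(c4ccc(OC[C@@H]5CO[C@@](Cn6cnnn6)(c6ccc(Cl)cc6Cl)O5)cc4)CC3)cc2)c1=O`, 0.321 ug/mL
compound 2, `CCC(C)n1ncn(-c2ccc(N3CCN(c4ccc(OC[C@@H]5CO[C@@](Cn6cnnn6)(c6ccc(Cl)cc6Cl)O5)cn4)CC3)cc2)c1=O`, 0.951 ug/mL
compound 3, `CCC(C)n1ncn(-c2ccc(N3CCN(c4ccc(OC[C@@H]5CO[C@@](Cn6cnnn6)(c6ccc(Cl)cc6Cl)O5)cc4)CC3)c(F)c2)c1=O`, 0.0528 ug/mL

Of the compounds shown here, three have been measured in a physicochemical assay for solubility, read by HPLC, measured as thermodynamic solubility; on this read-out lower numbers stand for lower solubility and higher numbers for higher solubility. Compound 1 `CCC(C)n1ncn(-c2ccc(N3CCN(c4ccc(OC[C@@H]5CO[C@@](Cn6cnnn6)(c6ccc(Cl)cc6Cl)O5)cc4)CC3)cc2)c1=O` gives 0.321 ug/mL in this assay . Compound 2 `CCC(C)n1ncn(-c2ccc(N3CCN(c4ccc(OC[C@@H]5CO[C@@](Cn6cnnn6)(c6ccc(Cl)cc6Cl)O5)cn4)CC3)cc2)c1=O` gives 0.951 ug/mL, the highest of the three numbers . Compound 3 `CCC(C)n1ncn(-c2ccc(N3CCN(c4ccc(OC[C@@H]5CO[C@@](Cn6cnnn6)(c6ccc(Cl)cc6Cl)O5)cc4)CC3)c(F)c2)c1=O` gives 0.0528 ug/mL, the lowest of the three .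

Compound 3 differs from compound 1 in one place: fluoro in place of hydrogen on an aromatic carbon. This change produced a 6.1-fold lower number from compound 1 to compound 3 (0.78 log units; beyond the scatter). Compound 2 stands apart from compound 1 by more than one place; the difference between the two cores is not broken down here.

Compound 4 `CCC(C)n1ncn(-c2ccc(N3CCN(c4ccc(OC[C@@H]5CO[C@@](Cn6cnnn6)(c6ccc(Cl)cc6Cl)O5)cn4)CC3)c(F)c2)c1=O` has not yet been measured in this assay . It differs from compound 2 in exactly the same way that compound 3 differs from compound 1: fluoro in place of hydrogen on an aromatic carbon. The place where the fluoro enters is described in the same words for both pairs, so the change is the same.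

Among the compounds with values here, since the same change is being made on a core that already differs, there is only one earlier step to rest on. Compound 4 is expected to show a 5.9-fold lower number from compound 2 to compound 4 (0.77 log units; beyond the scatter), taking the earlier step of a 6.1-fold lower number from compound 1 to compound 3 (0.78 log units; beyond the scatter) as the guide . On that basis compound 4 is estimated at 0.16 ug/mL in this assay , with an expected range from 0.06 ug/mL to 0.45 ug/mL.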

Compound 4, solubility: 0.708 ug/mL
Compound 4: the middle estimate sits 4.4-fold (0.65 log units) below what was measured; the measured number lies above the stated range.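

In this assay, fluoro in place of hydrogen on an aromatic carbon gave a 1.3-fold lower number from compound 2 to compound 4 (0.13 log units; within the scatter), whereas the same change had given a 6.1-fold lower number from compound 1 to compound 3 (0.78 log units; beyond the scatter). The step beyond the scatter on the core of compound 1 therefore did not carry over to the core of compound 2, where the step stays within the scatter, so in this series the size of the first step was no reliable guide to the second. With only one pair on each core, this does not show how the change would behave on any further core, nor does it establish a general rule for either core, and nothing in the data shown explains why the two steps part ways.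

The compounds shown leave open whether another small group in the same place, such as chloro or nitrile, would also give different steps on the two cores, or whether this is particular to fluoro. They also leave open whether an amine or a carboxylic acid placed elsewhere on these compounds would shift the read-out by a similar amount on both cores.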